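A few compounds are considered here, and "the series" means these few. Any claim that something is new, unique, unknown or untested is made for them only; others in the source may bear on it.

Compound 1 `CCCCc1ccc(C(=O)Nc2cc(C(=O)O)cc(C(=O)O)c2)cc1` – 91.9 mg/kg
Compound 2 `O=C(Nc1ccccc1)c1cccc(-c2nn[nH]n2)c1` – 38.1 mg/kg

In a functional assay on the whole organism (stomach) with Rattus norvegicus as the target (a higher number here means that more compound is needed for the effect, a lower number that less compound is needed), compound 1 has the higher number of the two at 91.9 mg/kg, and the gap down to compound 2 at 38.1 mg/kg lies beyond the usual scatter. Compound 3 `O=C(O)c1ccc(C(=O)Nc2cc(C(=O)O)cc(C(=O)O)c2)cc1` carries carboxy in place of butyl on an aromatic carbon, para to a large group: carboxy in place of butyl on an aromatic carbon. Among the compounds with values here, no measured pair isolates this change, so the forecast is tentative. A small rise in this assay is expected, possibly no larger than the scatter. The expected step is a 1.3-fold higher number from compound 1 to compound 3 (0.12 log units; within the scatter). For compound 3 the estimated value is 120 mg/kg, with an expected range from 40 mg/kg to 350 mg/kg.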

Compound 3, dose for 50% inhibition: 32.2 mg/kg
Compound 3: the middle estimate sits 3.7-fold (0.57 log units) above what was measured, outside the stated range (below it).
By their numbers in this assay, from the lowest: compounds 3 and 2 (each within the scatter of the next); then compound 1.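

In this assay, carboxy in place of butyl on an aromatic carbon, para to a large group, gives a 2.9-fold lower number from compound 1 to compound 3 (0.46 log units; beyond the scatter) and so less compound is needed with carboxy at this position. Within the data shown here, this is the first step in the set that changes one place alone, and it shows that butyl is not required there for the effect. Nothing available explains why the number falls. As far as these compounds go, whether an amine, a hydroxyl or a longer chain at this position would lower the number as well stays open, so the step cannot yet be read as a trend.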